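Bromo analogue: amide chain extended by one carbon

The source may hold more compounds than are shown below. What is called first, only, known or untested is meant among the compounds shown, and "the series" means these compounds.

Measured compounds in a functional assay on NCI-H460 cells (Homo sapiens) for antiproliferative activity, read by MTT assay, with a stated time of 72 h; a lower number here means a stronger inhibitor, a higher number a weaker inhibitor:
compound 1 `CCNC(=O)c1cc(Oc2ccc(NC(=O)c3cc4cccnc4n(-c4ccccc4F)c3=O)cc2)ccn1` gives 1230 nM
compound 3 `CCNC(=O)c1cc(Oc2ccc(NC(=O)c3cc4cccnc4n(-c4ccc(Br)cc4F)c3=O)cc2)ccn1` gives 1790 nM
compound 2 `CCNC(=O)c1cc(Oc2ccc(NC(=O)c3cc4cccnc4n(-c4ccc(Br)cc4)c3=O)cc2)ccn1` is recorded as "not determined" (no result reported)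

Compound 2 therefore stands without a number of its own in this assay; its nearest measured relatives are compound 1 and compound 3, whose values lie close together, the step of a 1.5-fold higher number from compound 1 to compound 3 (0.16 log units; within the scatter) being a change on the aromatic ring attached to the core. Compound 4 `CCCNC(=O)c1cc(Oc2ccc(NC(=O)c3cc4cccnc4n(-c4ccc(Br)cc4)c3=O)cc2)ccn1` differs from compound 2 by methyl in place of hydrogen on a saturated chain carbon, two bonds along the chain from an amide-type nitrogen. For the measured compounds named here, no measured step covers this kind of change, so the only guide is that the two measured compounds sit in the same narrow band. Compound 4 is therefore expected to land in that band, with an estimate of 1600 nM and a range from 700 nM to 3600 nM.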

Compound 4, half-maximal inhibitory concentration: 620 nM
For compound 4 the middle estimate is 2.6-fold (0.41 log units) above the measured one, and the stated range ends above it.
By their numbers in this assay, from the lowest: compounds 4, 1 and 3 (each within the scatter of the next, the first and the last beyond it).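

For the compounds shown here, compound 2 has no number in this assay, so no step from it to compound 4 can be read. Nothing at hand explains the value of compound 4. On these data alone, whether changing ethylamino to propylamino shifts activity on this bromo analogue stays open.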